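Working notes: replacing the amine of compound 2

The compounds below may be only part of what the source reports. "The series", "measured", "known", "first", "only" and "open" are said of these compounds alone.

In a functional assay on MES-SA/Dx5 cells (Homo sapiens) for inhibition, with a stated time of 72 h (a higher number here means a weaker inhibitor, a lower number a stronger inhibitor), compound 2 (`COCc1cc(CN2CCCC2)c(O)c2ncccc12`) gives 1350 nM on the shared core. Compound 3 (`CCOCc1cc(CN2CCCC2)c(O)c2ncccc12`) gives 912 nM and compound 1 (`Oc1c(CN2CCCC2)ccc2cccnc12`) gives 1470 nM; 1450 nM (2 entries) in the same assay. The repeat readings are close: the several entries of compound 1 in this assay, 1470 nM; 1450 nM (2 entries) agree well.

Among the measured compounds shown here, the only measured step between compounds that differ in one place is a 1.5-fold lower number from compound 2 to compound 3 (0.17 log units; within the scatter) and so compound 2 stands within the scatter of its one measured neighbour. That step leaves the pyrrolidin-1-yl group untouched.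

The change to compound 4 (`COCc1cc(CN2CCC(C)CC2)c(O)c2ncccc12`) is 4-methylpiperidin-1-yl in place of pyrrolidin-1-yl on a saturated chain carbon bound to an aromatic carbon where 4-methylpiperidin-1-yl takes the place of pyrrolidin-1-yl. For the measured compounds named here, no measured pair tests this exchange, so the evidence for its size is indirect and the range is kept wide.

Going by the values given here, with a 1.5-fold lower number from compound 2 to compound 3 (0.17 log units; within the scatter) as the only guide, no step beyond the scatter is expected in this assay and no firm direction can be given. The estimated step is a 1.4-fold lower number from compound 2 to compound 4 (0.13 log units; within the scatter) and it is expected to stay small. In this assay compound 4 is estimated at 1000 nM with an expected range from 400 nM to 2500 nM.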

Compound 4, half-maximal inhibitory concentration: 575 nM
Compound 4: the middle estimate sits 1.7-fold (0.24 log units) above what was measured; low and high end bracket the measured number.
By their numbers in this assay, from the lowest: compounds 4, 3 and 2 (each within the scatter of the next, the first and the last beyond it).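

Among the compounds shown here, the exchange on the saturated chain carbon bound to an aromatic carbon gives the first step that lies beyond the scatter, though a modest one (a 2.3-fold lower number from compound 2 to compound 4 (0.37 log units; beyond the scatter)). The earlier step on the ether chain (a 1.5-fold lower number from compound 2 to compound 3 (0.17 log units; within the scatter)) stayed within the scatter, so in this assay this amine position is the one shown to move the number. The repeat readings on a related compound are tight enough to support reading this modest step as real: the several entries of compound 1 in this assay, 1470 nM; 1450 nM (2 entries)

The exchange alters ring size and adds a methyl group at once, so the shown compounds cannot assign the step to either change; plain piperidin-1-yl would separate the two. From the compounds shown here alone, whether a hetero atom in the ring is tolerated remains open, and morpholin-4-yl would test that.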